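A few compounds are considered here, and "the series" means these few. Any claim that something is new, unique, unknown or untested is made for them only; others in the source may bear on it.

In a functional assay on HCT-116 cells (Homo sapiens) for antiproliferative activity, read by MTT assay, with a stated time of 48 h (a higher number here means a weaker inhibitor, a lower number a stronger inhibitor), three compounds sharing one core have been measured. Compound 1 `COc1ccc(N(C)c2ccnc(Cl)n2)cc1[N+](=O)[O-]`, the nitro member, gives 4700 nM. Compound 2 `COc1ccc(N(C)c2ccnc(Cl)n2)cc1O`, the hydroxy member, gives 422 nM, and compound 3 `COc1ccc(N(C)c2ccnc(Cl)n2)cc1OCCBr`, the 2-bromoethoxy member, gives 5670 nM. Compound 3 therefore stands with compound 1 at the high end of these numbers, as the step of a 1.2-fold higher number from compound 1 to compound 3 (0.08 log units; within the scatter) shows, and well away from the remaining member, as the step of a 13-fold higher number from compound 2 to compound 3 (1.13 log units; beyond the scatter) shows.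

Compound 4 `COc1ccc(N(C)c2ccnc(Cl)n2)cc1OCC[Se]C#N` keeps all of compound 3 except the end of the chain: a group of 3 heavy atoms (1 carbon, 1 nitrogen, 1 selenium; no ring) in place of one bromine atom, on a saturated chain carbon, two bonds along the chain from an oxygen on an aromatic ring. Among the compounds with values here, no measured step alters this chain end, so the evidence is indirect. The step of an 11-fold lower number from compound 1 to compound 2 (1.05 log units; beyond the scatter) and the step of a 13-fold higher number from compound 2 to compound 3 (1.13 log units; beyond the scatter) show that changes in this part of the molecule can be large, while the step of a 1.2-fold higher number from compound 1 to compound 3 (0.08 log units; within the scatter) shows that a change here can also leave the number within the scatter. Compound 2, at 422 nM, marks how low the set reaches, and a moderate move toward lower numbers is expected, held loosely. The expected change is a 3.2-fold lower number from compound 3 to compound 4 (0.50 log units; beyond the scatter). Compound 4 is estimated at 1800 nM, with an expected range from 300 nM to 7000 nM.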

Compound 4, half-maximal inhibitory concentration: 1220 nM
The estimate for compound 4 lay 1.5-fold (0.17 log units) above the measured number; the measured number falls inside the stated range.
By their numbers in this assay, from the lowest: compound 2; then compound 4; then compounds 1 and 3 (each within the scatter of the next).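

In this assay, within the data shown here, the end of the chain proves to matter in its own right: the group of 3 heavy atoms (1 carbon, 1 nitrogen, 1 selenium; no ring) in place of bromo, on a saturated chain carbon, gives a 4.6-fold lower number from compound 3 to compound 4 (0.67 log units; beyond the scatter), whereas the earlier steps altered nothing at this chain end. Compound 4 also falls between the other two members, with a 3.9-fold lower number from compound 1 to compound 4 (0.59 log units; beyond the scatter) and a 2.9-fold higher number from compound 2 to compound 4 (0.46 log units; beyond the scatter), so a chain on this oxygen need not leave the number level with the nitro member, as compound 3 does, although this chain does not reach the hydroxy member. No measurement here bears on why this change lowers the number.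

The compounds shown leave open which atoms of the new group carry the step, and how a thiocyanate with sulfur in place of selenium, a plain nitrile on the same chain, or a longer chain would stand. They also leave open how an amine in place of the hydroxy of compound 2 would compare.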